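The source may report more compounds than this note shows. Statements on the series, on what has been measured and on what is new or still open speak of the compounds shown alone.

Notes on the series. Compound 1 `O=C1N(Cc2ccccc2)c2cccn2S(=O)(=O)N1Cc1ccccc1` in an ADME assay on MT4 cells (Homo sapiens) for cytotoxicity, read by MTT assay, with a stated time of 5 days (on this read-out higher numbers stand for lower toxicity in this test and lower numbers for higher toxicity in this test), gives 196000 nM. Compound 2 `CC(C)=CCN1C(=O)N(Cc2ccccc2)S(=O)(=O)n2cccc21` gives 226000 nM, and compound 3 `N#CCN1C(=O)N(Cc2ccccc2)S(=O)(=O)n2cccc21` gives 180000 nM. The steps of a 1.1-fold lower number from compound 1 to compound 3 (0.04 log units; within the scatter) and a 1.3-fold lower number from compound 2 to compound 3 (0.10 log units; within the scatter) place compound 3 inside the usual scatter of both other compounds, and a 1.2-fold higher number from compound 1 to compound 2 (0.06 log units; within the scatter) shows the same for that pair. Compound 4 `O=C1N(Cc2ccc(F)cc2)c2cccn2S(=O)(=O)N1Cc1ccccc1` differs from compound 3 by 4-fluorophenyl in place of cyano on a saturated chain carbon bound to an amide-type nitrogen in a ring. Within the data shown here, the measured step that bears on this change is the exchange of phenyl for cyano in a 1.1-fold lower number from compound 1 to compound 3 (0.04 log units; within the scatter), which stayed within the scatter; the added fluorine has no measured precedent here. Compound 4 is therefore expected to move by a 1.1-fold higher number from compound 3 to compound 4 (0.05 log units; within the scatter), nothing beyond the scatter. For compound 4 the estimate is 200000 nM, with a range from 110000 nM to 350000 nM.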

Compound 4, half-maximal cytotoxic concentration: 150000 nM
Compound 4: the middle estimate sits 1.3-fold (0.12 log units) above what was measured; low and high end bracket the measured number.
By their numbers in this assay, from the lowest: compounds 4, 3, 1 and 2 (each within the scatter of the next).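

In this assay the 4-fluorophenyl group on this saturated chain carbon stays within the scatter of all three earlier compounds, with a 1.2-fold lower number from compound 3 to compound 4 (0.08 log units; within the scatter) and a 1.5-fold lower number from compound 2 to compound 4 (0.18 log units; within the scatter) as the steps from cyano and 2-methylprop-1-en-1-yl. Fluoro in place of hydrogen on an aromatic carbon now has its first reading, a 1.3-fold lower number from compound 1 to compound 4 (0.12 log units; within the scatter) and also within the scatter. Nothing measured here explains these numbers. Still open, going by these compounds, is whether an amine or a carboxylic acid on this chain carbon would give a step beyond the scatter.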